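A few compounds are considered here, and "the series" means these few. Any claim that something is new, unique, unknown or untested is made for them only; others in the source may bear on it.

In a functional assay on the whole organism (strain Swiss albino) with Mus musculus as the target, with a stated time of 4 h (on this read-out lower numbers stand for an effect already at smaller amounts and higher numbers for an effect only at larger amounts of compound), compound 3 `CC(C)=CC/C=C(/C)C/C=N/NC(=O)Nc1nnc(-c2ccc(F)cc2)o1` gives 300 mg/kg. It is surrounded by two close relatives at the same level: compound 1 `C=C(C)[C@@H]1CC=C(C)/C(=N/NC(=O)Nc2nnc(-c3ccccc3O)o2)C1` gives 300 mg/kg, and compound 2 `CC(C)=CC/C=C(/C)C/C=N/NC(=O)Nc1nnc(-c2ccc(Cl)cc2)o1` gives 300 mg/kg, so the three measured compounds stand together within the scatter. Among the compounds with values here, the only single-point step measured so far is no change at the digits printed from compound 2 to compound 3 (within the scatter), which shows that exchanging one halogen for another on the aromatic ring left this assay unmoved.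

Compound 4 `CC(C)=CC/C=C(/C)C/C=N/NC(=O)Nc1nnc(-c2ccc(O)cc2)o1` is the next member of the series, differing from compound 3 by hydroxy in place of fluoro on an aromatic carbon. Within the data shown here, no measured pair isolates this particular change; the halogen swap is the nearest guide, and compound 1, which also carries a hydroxy group on its aromatic ring, sits at the same level as compound 3. On that basis the step of no change at the digits printed from compound 3 to compound 4 (within the scatter) is expected to stay within the scatter. Compound 4 is therefore estimated to give 300 mg/kg, with a range from 150 mg/kg to 600 mg/kg.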

Compound 4, minimum effective dose: 300 mg/kg
Compound 4: middle estimate and measured number agree at the digits printed; low and high end bracket the measured number.
By their numbers in this assay, from the lowest: compounds 1, 2, 3 and 4 (each within the scatter of the next).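

In this assay the change from 4-fluorophenyl to 4-hydroxyphenyl gives no change at the digits printed from compound 3 to compound 4 (within the scatter) and hydroxy in place of chloro gives no change at the digits printed from compound 2 to compound 4 (within the scatter) on the same ring. Until now only halogens had been compared on an aromatic carbon para to a large group; these steps extend the flat result to a group that brings a hydrogen-bond donor and acceptor, which fluoro and chloro do not. Nothing given here accounts for this flat result.

On these data alone, whether an amine, a carboxylic acid or a longer chain at this place would move the read-out stays open. Also open, as far as these compounds go, is whether a phenyl ring with no group at this place would read the same as compounds 2, 3 and 4.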